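The source may report more compounds than this note shows. Statements on the series, on what has been measured and on what is new or still open speak of the compounds shown alone.

Measured so far in a functional assay on A549 cells (Homo sapiens) for cytotoxicity, read by MTT assay, with a stated time of 48 h; a lower number here means a stronger inhibitor, a higher number a weaker inhibitor:

compound 1 `Cc1ccc(S(=O)(=O)/N=C(/CCNC2=CC(=O)c3ccccc3C2=O)Nc2ccccc2I)cc1`: 24700 nM
compound 2 `Cc1ccc(S(=O)(=O)/N=C(/CCNC2=CC(=O)c3ccccc3C2=O)Nc2cccc(C(F)(F)F)c2)cc1`: 78500 nM
compound 3 `Cc1ccc(S(=O)(=O)/N=C(/CCNC2=CC(=O)c3ccccc3C2=O)Nc2cc(F)c(F)c(F)c2)cc1`: 10200 nM

Compound 3 stands lowest of the three numbers: the nearest is compound 1 and the furthest compound 2, both steps beyond the scatter. The measured steps all exchange one six-membered aromatic ring on the amine nitrogen for another: a 3.2-fold higher number from compound 1 to compound 2 (0.50 log units; beyond the scatter), a 2.4-fold lower number from compound 1 to compound 3 (0.38 log units; beyond the scatter) and a 7.7-fold lower number from compound 2 to compound 3 (0.89 log units; beyond the scatter). The whole spread across these three rings stays modest.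

Compound 4 `Cc1ccc(S(=O)(=O)/N=C(\N)CCNC2=CC(=O)c3ccccc3C2=O)cc1` goes one step further: hydrogen in place of 3,4,5-trifluorophenyl on an amine nitrogen. Within the data shown here, none of the measured steps removes the ring altogether, so the bearing of the three steps is indirect; they only show that the identity of the ring shifts the number by modest amounts, and that compound 3 holds the most favourable of the three. Losing the ring entirely is taken as more likely to raise the number than to lower it, and by a step at least as large as the ring-to-ring exchanges, hence an expected 3.4-fold higher number from compound 3 to compound 4 (0.54 log units; beyond the scatter). Compound 4 is therefore estimated at 35000 nM in this assay, with a range from 9000 nM to 130000 nM.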

Compound 4, half-maximal inhibitory concentration: 26600 nM
Beside the measured number, compound 4's estimate is 1.3-fold (0.12 log units) above it; the range from low to high includes it.
By their numbers in this assay, from the lowest: compound 3; then compounds 1 and 4 (each within the scatter of the next); then compound 2.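

Taking the aromatic ring off the amine nitrogen altogether does not remove the effect in this assay, so the ring is not needed for a measurable number in this series, and compound 4 now serves as the ring-free reference for this position. Against that reference the three rings part ways: hydrogen in place of 3,4,5-trifluorophenyl gives a 2.6-fold higher number from compound 3 to compound 4 (0.42 log units; beyond the scatter), hydrogen in place of 3-(trifluoromethyl)phenyl gives a 3.0-fold lower number from compound 2 to compound 4 (0.47 log units; beyond the scatter), and hydrogen in place of 2-iodophenyl gives a 1.1-fold higher number from compound 1 to compound 4 (0.03 log units; within the scatter), so among these rings only 3,4,5-trifluorophenyl improves on the bare amino group, 3-(trifluoromethyl)phenyl does worse than it, and 2-iodophenyl cannot be told apart from it. Nothing at hand bears on why the rings divide in this way.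

The compounds shown leave open how an unsubstituted phenyl, a benzyl or a simple methyl on this nitrogen would fall relative to the amino group of compound 4. They also leave open whether a single fluorine on the ring is enough to give a step like that of the 3,4,5-trifluorophenyl group.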